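A few compounds are considered here, and "the series" means these few. Any claim that something is new, unique, unknown or untested is made for them only; others in the source may bear on it.

Measured compounds:
- compound 1, `CSc1ccc(C(=O)/C=C/c2ccc([N+](=O)[O-])o2)cc1`, 13100 nM
- compound 2, `O=C(/C=C/c1ccc([N+](=O)[O-])s1)c1ccc(C2CCCCC2)cc1`, > 50000 nM

These two compounds share a core built from an unsaturated ketone that links a nitro-substituted five-membered ring to a benzene ring. In an ADME assay on THP-1 cells (Homo sapiens) for cytotoxicity, read by resazurin assay, with a stated time of 72 h (on this read-out higher numbers stand for lower toxicity in this test and lower numbers for higher toxicity in this test), compound 1 gives 13100 nM. Compound 2 reaches only > 50000 nM in this assay, which is a limit of the test and not a number. Compound 1 therefore holds the only real number shown; the other result is the limit of > 50000 nM in this assay, at which 1 of the 2 values shown sits. Among the measured compounds shown here, no two measured compounds differ in one place only, so no single step can be read off.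

Compound 3, `O=C(/C=C/c1ccc([N+](=O)[O-])o1)c1ccc(N2CCCC2)cc1`, is not yet measured. It differs from compound 1 in one place: pyrrolidin-1-yl in place of methylsulfanyl on an aromatic carbon, para to a large group. For the measured compounds named here, with no measured step of this kind to lean on, the size of the step from compound 1 to compound 3 is uncertain; a change of modest size in either direction, or none beyond the scatter, is equally plausible. The step of a 1.3-fold lower number from compound 1 to compound 3 (0.12 log units; within the scatter) is therefore expected to be small. Compound 3 is expected to give about 10000 nM in this assay, within a range from 3000 nM to 40000 nM.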

Compound 3, half-maximal cytotoxic concentration: > 50000 nM
Compound 3 was reported as a limit; the forecaster's own chance of this, stated with the estimate: 15%; middle value at least 5.0-fold (0.69 log units) from the limit.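

At this position on the six-membered aromatic ring of carbon only, para to a large group, pyrrolidin-1-yl in place of methylsulfanyl gives an at least 3.8-fold higher number from compound 1 to compound 3 (0.58 log units; beyond the scatter) in this assay and so shows that the group here can by itself move the read-out beyond the scatter, towards lower toxicity in this test. Going by these compounds, compound 3 gives > 50000 nM and this is a limit of the assay and not a number, so the full size of the step remains unknown. Only compound 1 now holds a real number in this test: the limit of > 50000 nM in this assay, at which 2 of the 3 values shown sit.

The compounds shown leave open whether the shift follows the ring of pyrrolidin-1-yl, its nitrogen or its larger count of heavy atoms. A dimethylamino group or a piperidin-1-yl ring at this position on the core of compound 1 could begin to separate these possibilities, and a result below the limit would be needed to give such a step a full size.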